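The source may report more compounds than this note shows. Statements on the series, on what has been measured and on what is new or still open speak of the compounds shown alone.

Measured in a physicochemical assay for lipophilicity, read by mass spectrometry; a higher number here means a more lipophilic compound, a lower number a more polar compound:
- compound 1 `CCOc1ccc(NC(=O)C2Cc3cc(OC)c(OC)cc3C2=O)cc1`: 2.42
- compound 2 `COc1cc2c(cc1OC)C(=O)C(C(=O)Nc1ccc(F)cc1)C2`: 2.36
- compound 3 `COc1cc2c(cc1OC)C(=O)C(C(=O)Nc1ccc(Cl)cc1)C2`: 2.76

Among these three, compound 3 stands highest, at 2.76. The two steps that reach it are a number 0.34 log units higher from compound 1 to compound 3 (beyond the scatter) and a number 0.40 log units higher from compound 2 to compound 3 (beyond the scatter).

The next structure is compound 4 `COc1cc2c(cc1OC)C(=O)C(C(=O)Nc1ccc(Br)cc1)C2`, which keeps everything in compound 3 except one group: bromo in place of chloro on an aromatic carbon. This is bromo in place of chloro on an aromatic carbon, para to a large group.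

Among the compounds with values here, the closest guide is the only measured exchange of one halogen for another, chloro in place of fluoro, which gave a number 0.40 log units higher from compound 2 to compound 3 (beyond the scatter). The steps away from ethoxy say less, though they complete the picture: a number 0.06 log units lower from compound 1 to compound 2 (within the scatter) and a number 0.34 log units higher from compound 1 to compound 3 (beyond the scatter). Within the data shown here, no measured compound carries bromo, so the size of this step rests on thin evidence.

Going by a number 0.40 log units higher from compound 2 to compound 3 (beyond the scatter), another rise is expected, though a smaller one that may not clear the scatter. The expected step is a number 0.16 log units higher from compound 3 to compound 4 (within the scatter). For compound 4 the estimated value is 2.92, with an expected range from 2.68 to 3.16.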

Compound 4, partition coefficient: 3.03
The estimate for compound 4 lay 0.11 log units below the measured number, and the stated range covers the measured number.
By their numbers in this assay, from the lowest: compounds 2 and 1 (each within the scatter of the next); then compounds 3 and 4 (each within the scatter of the next).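

The new value shows that at this position, on an aromatic carbon para to a large group, the exchange of chloro for bromo gives a number 0.27 log units higher from compound 3 to compound 4 (within the scatter) in this assay, so the two heavier halogens cannot be told apart here, even though the chloro-for-fluoro exchange had cleared the scatter. Bromo, like chloro, stands clear of both of the other groups, with a number 0.67 log units higher from compound 2 to compound 4 (beyond the scatter) and a number 0.61 log units higher from compound 1 to compound 4 (beyond the scatter), so among these four compounds the para substituents fall into two sets: fluoro and ethoxy in one, chloro and bromo in the other, and that split does not follow a simple line through the halogens, as fluoro sits with the non-halogen ethoxy. Nothing shown here accounts for the size of these steps or for this grouping.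

From the compounds shown here alone, what a carboxylic acid, an amine or a longer alkoxy chain such as propoxy would give at this same position stays open. Going by these compounds, it is also open whether chloro and bromo would stay this close at another place on the 4-chlorophenyl ring or on the shared core, as every exchange shown sits at this one position.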